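A few compounds are considered here, and "the series" means these few. Any claim that something is new, unique, unknown or untested is made for them only; others in the source may bear on it.

Working notes on the series. Compound 1 `COc1ccc(COc2ccc3c(c2)[C@@H](O)CN(C)C3)cc1` in an ADME assay on Vero cells (Chlorocebus sabaeus) for cytotoxicity, read by sulforhodamine B assay, with a stated time of 72 h (a lower number here means a stronger inhibitor, a higher number a weaker inhibitor), gives only a limit, > 50000 nM. Compound 3 `CN1Cc2ccc(OCCCc3ccccc3)cc2[C@@H](O)C1` in this assay likewise gives only a limit, > 50000 nM. Compound 2 `Cc1ccccc1COc1ccc2c(c1)[C@@H](O)CN(C)C2` in this assay also gives only a limit, > 100000 nM. Compound 2 therefore stands at the limit of > 100000 nM in this assay, at which 1 of the 3 values shown sits, whereas the other two values rest at the limit of > 50000 nM in this assay, at which 2 of the 3 values shown sit; no number ranks the three.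

Compound 4 `CN1Cc2ccc(OCc3cccnc3)cc2[C@@H](O)C1` is not yet measured; it differs from compound 2 by pyridin-3-yl in place of 2-methylphenyl on a saturated chain carbon bound to an oxygen on an aromatic ring. No step between measured compounds is available, and every shown value is a limit, so no step beyond the scatter is expected in this assay, the expected step being a number no higher from compound 2 to compound 4 (the limit leaves the size open). Compound 4 is estimated at 100000 nM, in the range 50000 nM to 300000 nM, most likely reported again only as a limit.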

Compound 4, half-maximal inhibitory concentration: > 50000 nM
Compound 4 ended at the assay's limit (the forecaster's own chance of this, stated with the estimate: 85%); the middle value lies beyond the limit too.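

Compound 2 and compound 4 both give only limits in this assay, so no step can be read between them. The compounds shown leave open whether pyridin-3-yl in place of 2-methylphenyl changes the read-out at all.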